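The source may report more compounds than this note shows. Statements on the series, on what has been measured and on what is new or still open speak of the compounds shown alone.

In a functional assay on HT-29 cells (Homo sapiens) for inhibition (a lower number here means a stronger inhibitor, a higher number a weaker inhibitor), compound 1 `Oc1ccc(/C=C/c2ccc3ccccc3c2)cc1` gives 4060 nM. Compound 2 `COc1ccc(/C=C/c2ccc3ccccc3c2)cc1` reads > 5000 nM, which is a limit of the assay and not a number. Compound 3 `COc1ccc(/C=C/c2ccc3ccccc3c2)cc1[N+](=O)[O-]` differs from compound 2 in one place: nitro in place of hydrogen on an aromatic carbon. Among the compounds with values here, only one measured step exists, an at least 1.2-fold higher number from compound 1 to compound 2 (0.09 log units; that floor lies within the scatter), and it concerns a methyl on an oxygen, not a nitro, so it gives little guide to size or direction. No step beyond the scatter is therefore expected, and the estimated step is a number no higher from compound 2 to compound 3 (the limit leaves the size open). The expected value for compound 3 is 5000 nM, within an estimated range of 1500 nM to 15000 nM.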

Compound 3, half-maximal inhibitory concentration: > 5000 nM
Compound 3 gave a limit, no number; the forecaster's own chance of this, stated with the estimate: 60%; the middle value sits exactly at the limit.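

In this assay, within the data shown here, compound 2 and compound 3 both give only a limit of the assay, not a number, so no step between them can be read. The compounds shown leave open how strongly either one inhibits and whether the nitro changes that.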